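Swapping a Dimethylamino Tail for Benzyl

This account rests on a few compounds, and the source may have more. Where it says the series, first, only, none or still open, it means among the compounds named here.

Three measured compounds share one core and differ only in the group attached to a nitrogen on an aromatic ring. Compound 1 `CCCC(=O)Nc1ncc(-c2cccc(Cl)c2)c(-c2ccccc2)n1` carries propylcarbonyl there, compound 2 `CC(C)CCNc1ncc(-c2cccc(Cl)c2)c(-c2ccccc2)n1` carries isopentyl, and compound 3 `CN(C)CCNc1ncc(-c2cccc(Cl)c2)c(-c2ccccc2)n1` carries 2-(dimethylamino)ethyl. All were tested in an assay on CHO cells for displacement of a labelled ligand from adenosine receptor A1 (Homo sapiens), read by scintillation counting, with a stated time of 1 h, tested at 1 uM; on this read-out lower numbers stand for less inhibition and higher numbers for more inhibition at the one concentration tested (going by the name of the read-out). Compound 1 reaches > 80%, which is a limit of the assay rather than a number (the limit of > 80% in this assay, at which 1 of the 3 values shown sits). Compound 2 gives 39% and compound 3 gives 52%, so among the two plain numbers compound 3 stands highest, a number 13 percentage points higher from compound 2 to compound 3 (beyond the scatter). Both sit well under compound 1: a number at least 41 percentage points lower from compound 1 to compound 2 (beyond the scatter) and a number at least 28 percentage points lower from compound 1 to compound 3 (beyond the scatter).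

Compound 4 `Clc1cccc(-c2cnc(NCCCc3ccccc3)nc2-c2ccccc2)c1` has not yet been measured. It differs from compound 3 as follows: benzyl in place of dimethylamino on a saturated chain carbon, two bonds along the chain from a nitrogen on an aromatic ring. The step that bears on this change runs from isopropyl to dimethylamino at the same chain carbon, where the reading rose modestly, a number 13 percentage points higher from compound 2 to compound 3 (beyond the scatter). Compound 4 moves back to a carbon-only group, benzyl, and is therefore expected to fall by a modest amount, a number 12 percentage points lower from compound 3 to compound 4 (beyond the scatter). In this assay compound 4 is estimated at 40%, with a likely range from 25% to 58%.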

Compound 4, a percentage reported as inhibition, at one concentration (the size of the read-out at that concentration, not a potency): 33%
For compound 4 the middle estimate is 7 percentage points above the measured one; low and high end bracket the measured number.
By their numbers in this assay, from the lowest: compounds 4 and 2 (each within the scatter of the next); then compound 3. At a limit, above all of these: compound 1.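

In this assay, the change at this chain carbon shows two different outcomes: a number 19 percentage points lower from compound 3 to compound 4 (beyond the scatter), whereas a number 6 percentage points lower from compound 2 to compound 4 (within the scatter). Among the three groups compared at this carbon, dimethylamino is the one that stands apart, while the ring of benzyl gives a reading that cannot be told from that of the open-chain isopropyl. The 3-phenylpropyl group also remains far from propylcarbonyl on the nitrogen, a number at least 47 percentage points lower from compound 1 to compound 4 (beyond the scatter), and compound 1 stands at a limit rather than a number: the limit of > 80% in this assay, at which 1 of the 4 values shown sits.

The compounds shown leave open whether another amine at this chain carbon, such as pyrrolidine or morpholine, would read like dimethylamino. They also leave open whether a hydroxyl group there would do the same, or whether the nitrogen of dimethylamino is specifically needed.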